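The compounds below may be only part of what the source reports. "The series", "measured", "known", "first", "only" and "open" are said of these compounds alone.

Compound 2 `Nc1nc(N)c2c(-c3ccccc3)cn([C@@H]3O[C@H](CO)[C@@H](O)[C@H]3O)c2n1` is the point of departure. In a functional assay on HCT-116 cells (Homo sapiens), read by MTT assay, with a stated time of 72 h (a higher number here means a weaker inhibitor, a lower number a stronger inhibitor), compound 2 gives > 20000 nM, which is a limit of the assay and not a measured number. Its closest neighbour, compound 1 `Cc1nc(N)c2c(-c3ccccc3)cn([C@@H]3O[C@H](CO)[C@@H](O)[C@H]3O)c2n1`, shows the same picture: in this assay compound 1 gives > 20000 nM, again a limit. For the measured compounds named here, the one measured step, a step that the two limits leave unreadable from compound 1 to compound 2, therefore has no readable size, because of the limit of > 20000 nM in this assay, at which 2 of the 2 values shown sit. Compound 3 `Nc1nc(N)c2c(-c3cc4ccccc4o3)cn([C@@H]3O[C@H](CO)[C@@H](O)[C@H]3O)c2n1` has not yet been tested; it differs from compound 2 by 1-benzofuran-2-yl in place of phenyl on an aromatic carbon. Going by the values given here, no measured step touches this part of the structure, so nothing in the data points to a direction for this change. With both known values sitting at the limit, the expectation is that compound 3 stays in the same region, the step of a number no higher from compound 2 to compound 3 (the limit leaves the size open) being the estimate. The estimated value for compound 3 in this assay is 20000 nM, expected to lie between 4000 nM and 60000 nM.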

Compound 3, half-maximal inhibitory concentration: 14000 nM
Compound 3: middle estimate off by 1.4-fold (0.15 log units), on the high side; the range from low to high includes it.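

On this aromatic carbon of the five-membered ring, putting 1-benzofuran-2-yl in place of phenyl gives, in this assay, an at least 1.4-fold lower number from compound 2 to compound 3 (0.15 log units; that floor lies within the scatter). For the compounds shown here, compound 3 is the first compound here to carry a number and not a limit, which makes this position the first place in the set where a step has a readable floor. That floor is all the data give, and it does not separate the two compounds: the limit of > 20000 nM in this assay, at which 2 of the 3 values shown sit.

Still open, from the compounds shown here alone, is which part of 1-benzofuran-2-yl matters, the ring oxygen or the added ring, a question that naphthalen-2-yl on the same carbon could address. Equally open, going by these compounds, is how an amine or a carboxylic acid at this position would read in this assay.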